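Replacing a Nitrophenyl Amide with a Methoxypyridyl Amide

The source may hold more compounds than are shown below. What is called first, only, known or untested is meant among the compounds shown, and "the series" means these compounds.

Measured compounds:
compound 1, `O=C(Nc1ccc([N+](=O)[O-])cc1)c1c(O)c2cccnc2n(-c2ccccc2)c1=O`: -25.8%
compound 2, `O=C(Nc1ccncc1)c1c(O)c2cccnc2n(-c2ccccc2)c1=O`: 24.3%

Within the data shown here, in a functional assay on the whole organism for inhibition, with Rattus norvegicus as the target, read by cytopathic effect and paw edema, at a dose of 100 mg/kg by the oral route (on this read-out higher numbers stand for more inhibition at the one dose given (going by the name of the read-out) and lower numbers for less inhibition), compound 1 gives -25.8%, the lower of the two numbers measured so far, and compound 2 gives 24.3%. Among the measured compounds shown here, the only measured step, a number 50.1 percentage points higher from compound 1 to compound 2 (beyond the scatter), puts pyridin-4-yl in place of 4-nitrophenyl on the amide-type nitrogen.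

Compound 3, `COc1ccc(NC(=O)c2c(O)c3cccnc3n(-c3ccccc3)c2=O)cn1`, has not yet been measured in this assay. It differs from compound 1 in one place: 6-methoxypyridin-3-yl in place of 4-nitrophenyl on an amide-type nitrogen. Here, as in the step from compound 1 to compound 2, the 4-nitrophenyl leaves and a six-membered aromatic ring with one hetero atom enters on the same nitrogen, so that step is the only one that bears on the change. As far as these compounds go, since that step was large and upward, a step of similar direction is expected for compound 3, a number 43.8 percentage points higher from compound 1 to compound 3 (beyond the scatter), though the methoxy substituent is untested. The estimated value for compound 3 is 18%, within a range from -12% to 48%.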

Compound 3, a percentage reported as inhibition, in the whole organism at one dose (the size of the read-out at that dose, not a potency): -10.2%
The estimate for compound 3 lay 28.2 percentage points above the measured number; measured number inside the range.
By their numbers in this assay, from the lowest: compound 1; then compound 3; then compound 2.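

In this assay, losing the 4-nitrophenyl from the amide-type nitrogen is not enough to reach the level of compound 2: the 6-methoxypyridin-3-yl group gives a number 15.6 percentage points higher from compound 1 to compound 3 (beyond the scatter), a modest step. Set against pyridin-4-yl, the same group gives a number 34.5 percentage points lower from compound 2 to compound 3 (beyond the scatter), a large step, so two six-membered aromatic rings with one hetero atom on the same nitrogen do not read alike here. No measurement at hand accounts for the gap between these two groups.

The compounds shown leave open whether that gap follows the methoxy group or the change from a pyridin-4-yl to a pyridin-3-yl ring. A plain pyridin-3-yl on the same nitrogen would bear on this question, and a 6-aminopyridin-3-yl would show how another group in the place of the methoxy reads.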